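A few compounds are considered here, and "the series" means these few. Any claim that something is new, unique, unknown or untested is made for them only; others in the source may bear on it.

Measured compounds:

compound 1 `CCC(CC)(c1ccc(OCCCCCCCO)c(C)c1)c1ccc(OCC(O)C(C)(C)C)c(OCC(O)C(C)(C)C)c1` — 5%
compound 2 `CCC(CC)(c1ccc(OCCCC(=O)O)c(C)c1)c1ccc(OCC(O)C(C)(C)C)c(OCC(O)C(C)(C)C)c1` — 14%
compound 3 `CCC(CC)(c1ccc(OS(C)(=O)=O)c(C)c1)c1ccc(OCC(O)C(C)(C)C)c(OCC(O)C(C)(C)C)c1` — "not active" (no number reported)

All three share the same core and were tested in an assay on cells for binding affinity to vitamin D3 receptor (Homo sapiens), read by fluorescence, tested at 1 uM; on this read-out lower numbers stand for less inhibition and higher numbers for more inhibition at the one concentration tested (going by the name of the read-out). Within the data shown here, the only step between two measured compounds that differ in one place is a number 9 percentage points higher from compound 1 to compound 2 (within the scatter); it concerns the chain on the other aromatic ring and not the group that changes here. For compound 3 no single number is reported: in this assay compound 3 is given only as "not active" (no number reported), so it stands at the low end of the series without a figure.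

The next compound, compound 4 `CCC(CC)(c1ccc(OS(=O)(=O)c2ccccc2)c(C)c1)c1ccc(OCC(O)C(C)(C)C)c(OCC(O)C(C)(C)C)c1`, differs from compound 3 in one place: phenyl in place of methyl on a sulfonyl sulfur. Read one bond further out this is methylsulfonyl to phenylsulfonyl. Among the measured compounds shown here, no measured step describes this kind of change, so nothing among the measured compounds bears directly on it; the one step available, from compound 1 to compound 2, was within the scatter and sits elsewhere on the molecule. The starting point, compound 3, is reported as not active with no number, and there is no evidence in the series for a change of size in either direction beyond the scatter. Compound 4 is therefore expected to remain low in this assay.

Compound 4 is estimated at 5%, with a range from -5% to 20%.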

Compound 4, a percentage reported as inhibition, at one concentration (the size of the read-out at that concentration, not a potency): "not active" (no number reported)
The entry for compound 4 holds no number; the estimate stays without a comparison.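

In this assay compound 3 is given as "not active" (no number reported) and compound 4 as "not active" (no number reported), so no new step can be read from this pair. No measured evidence bears on this result.

Left open is whether methylsulfonyl and phenylsulfonyl differ at all within the range reported as not active.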